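Swapping the Ring on the Amide Nitrogen of Compound 3

A few compounds are considered here, and "the series" means these few. Any claim that something is new, unique, unknown or untested is made for them only; others in the source may bear on it.

Measured compounds:
compound 1, `CN1CCC(CNS(=O)(=O)c2ccccc2Nc2cc(-c3ccc4ccn(C)c4c3)c3nccnc3c2)C1`: 11 nM
compound 2, `Cn1cc(CNS(=O)(=O)c2ccccc2Nc2cc(-c3ccc4ccn(C)c4c3)c3nccnc3c2)cn1`: 38 nM
compound 3, `Cn1ccc2ccc(-c3cc(Nc4cnccc4C(=O)NC4CCNC(=O)C4)cc4nccnc34)cc21`: 69 nM

All three were tested in an assay for inhibition of 6-phosphofructo-2-kinase/fructose-2,6-bisphosphatase 3 (Homo sapiens), read by ADP-Glo, with a stated time of 2 h; on this read-out higher numbers stand for weaker inhibition and lower numbers for stronger inhibition. Compound 3 holds the highest of the three numbers; its gap to compound 2 lies within the scatter, while its gap to compound 1 lies beyond it. Among the measured compounds shown here, the one directly comparable step, a 3.5-fold higher number from compound 1 to compound 2 (0.54 log units; beyond the scatter), replaces one saturated ring with a small aromatic one on the chain carbon bound to the sulfonamide nitrogen, and it was modest.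

Compound 4, `CC(=O)N1CC(NC(=O)c2ccncc2Nc2cc(-c3ccc4ccn(C)c4c3)c3nccnc3c2)C1`, differs from compound 3 by 1-acetylazetidin-3-yl in place of 2-oxopiperidin-4-yl on an amide-type nitrogen. For the measured compounds named here, no measured pair changes a group on an amide-type nitrogen, so the only guide is the modest size of the sulfonamide-side ring swap from compound 1 to compound 2. A change of similar or smaller size is expected in this assay, with no confident direction, and probably not beyond the scatter. That expectation amounts to a step of a 1.3-fold higher number from compound 3 to compound 4 (0.12 log units; within the scatter). Compound 4 is therefore estimated at 90 nM, with a range from 35 nM to 230 nM.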

Compound 4, half-maximal inhibitory concentration: 73 nM
Estimate against measurement, compound 4: 1.2-fold (0.09 log units) above, within the range that was stated.
By their numbers in this assay, from the lowest: compound 1; then compounds 2, 3 and 4 (each within the scatter of the next).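

In this assay, 1-acetylazetidin-3-yl in place of 2-oxopiperidin-4-yl on the amide-type nitrogen gives a 1.1-fold higher number from compound 3 to compound 4 (0.02 log units; within the scatter), so the two numbers cannot be told apart. Among the compounds shown here, this is the first step read at this place, and it shows that a four-membered non-aromatic ring carrying the acetyl group and a six-membered non-aromatic ring can stand here with the same atoms at no cost beyond the scatter, even though the hydrogen-bond donor of the group that leaves has no counterpart in the group that enters. No measurement is at hand that would account for this result.

On these data alone, whether this holds for a free amine such as unsubstituted azetidin-3-yl remains open. So does whether it holds for a carboxylic acid or a longer open chain on this amide-type nitrogen.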